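The source may hold more compounds than are shown below. What is called first, only, known or untested is meant among the compounds shown, and "the series" means these compounds.

Working notes on the series

Compound 1 `O=C(/C=C\Nc1ccc(Cl)cc1)c1cn(-c2ccccc2)nc1-c1ccc(F)cc1` is the reference point. In a functional assay on HT-29 cells (Homo sapiens) for antiproliferative activity, read by MTT assay, with a stated time of 48 h (a lower number here means a stronger inhibitor, a higher number a weaker inhibitor), compound 1 gives 4600 nM. Compound 2 `O=C(/C=C\Nc1ccc(C(F)(F)F)cc1)c1cn(-c2ccccc2)nc1-c1ccc(F)cc1` differs from compound 1 by trifluoromethyl in place of chloro on an aromatic carbon. In this assay compound 2 returns only a limit, > 50000 nM, and not a number. The step of an at least 10-fold higher number from compound 1 to compound 2 (1.03 log units; beyond the scatter) is therefore a lower bound on the change, because the limit of > 50000 nM in this assay, at which 1 of the 3 values shown sits, is where the reading stops.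

Compound 3 `COc1ccc(-c2nn(-c3ccccc3)cc2C(=O)/C=C\Nc2ccc(Cl)cc2)cc1` carries a different core, and the difference from compound 1 is methoxy in place of fluoro on an aromatic carbon. In this assay compound 3 gives 4760 nM. The step of a 1.0-fold higher number from compound 1 to compound 3 (0.01 log units; within the scatter) shows that the two cores read alike within this assay, so compound 1 and compound 3 are not ordered against each other.

Compound 4 `COc1ccc(-c2nn(-c3ccccc3)cc2C(=O)/C=C\Nc2ccc(C(F)(F)F)cc2)cc1` is not yet measured. It differs from compound 3 by trifluoromethyl in place of chloro on an aromatic carbon. The place lines for this change and for the change from compound 1 to compound 2 agree word for word, so the same change is made on the core of compound 3 as was made on the core of compound 1. The expected step in this assay is a 10-fold higher number from compound 3 to compound 4 (1.00 log units; beyond the scatter), resting on the measured step of an at least 10-fold higher number from compound 1 to compound 2 (1.03 log units; beyond the scatter) and on the matched starting values of compound 1 and compound 3. Because the limit of > 50000 nM in this assay, at which 1 of the 3 values shown sits, sits close to where that step would land, a limit rather than a number is a real possibility. Compound 4 is estimated at 48000 nM, with a range from 20000 nM to 150000 nM.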

Compound 4, half-maximal inhibitory concentration: 9870 nM
Beside the measured number, compound 4's estimate is 4.9-fold (0.69 log units) above it; measured number outside the range, below it.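

In this assay, trifluoromethyl in place of chloro gives a 2.1-fold higher number from compound 3 to compound 4 (0.32 log units; beyond the scatter), so on these two cores the direction of the change carries over but its size does not: the same change on two cores in this assay, an at least 10-fold higher number (1.03 log units; beyond the scatter) from compound 1 to compound 2 and a 2.1-fold higher number (0.32 log units; beyond the scatter) from compound 3 to compound 4, at least 5.2-fold (0.71 log units) apart, beyond the scatter of two such steps

Read the other way, methoxy in place of fluoro gives an at least 5.0-fold lower number from compound 2 to compound 4 (0.70 log units; beyond the scatter) when trifluoromethyl is present, and the two changes therefore do not add up independently across these four compounds: the same change on two cores in this assay, a 1.0-fold higher number (0.01 log units; within the scatter) from compound 1 to compound 3 and an at least 5.0-fold lower number (0.70 log units; beyond the scatter) from compound 2 to compound 4, at least 5.2-fold (0.71 log units) apart, beyond the scatter of two such steps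

Compound 2 stands at a limit, > 50000 nM, so the gap between the steps is known only as a lower bound, and nothing here shows why the change differs between the cores: the limit of > 50000 nM in this assay, at which 1 of the 4 values shown sits.

From the compounds shown here alone, it remains open whether this dependence on the core extends to a third group in place of chloro, such as a nitrile or a methyl, or to a third group in place of fluoro, such as a hydroxyl or an amine. Also open, going by these compounds, is whether a pattern resting on four compounds in one cell line would hold in other cells.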